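The source may report more compounds than this note shows. Statements on the series, on what has been measured and on what is new or still open speak of the compounds shown alone.

Measured so far in a functional assay on ileum (strain Hartley) for agonist activity at 5-hydroxytryptamine receptor 3A (Cavia porcellus); a lower number here means a less potent compound, a higher number a more potent compound, by a factor of ten per unit of this negative logarithm:
compound 1 `CCc1cc(C)cc2nc(N3CCN(C)CC3)oc12` gives 6.46
compound 2 `COc1cc(C)cc2nc(N3CCN(C)CC3)oc12` gives 6.13
compound 3 `Cc1cc(C)c2oc(N3CCN(C)CC3)nc2c1` gives 6.32

Compound 1 holds the highest of the three numbers. Compound 3 stands nearest to it, the step of a number 0.14 log units lower from compound 1 to compound 3 (within the scatter) lying within the scatter, and compound 2 stands furthest, the step of a number 0.33 log units lower from compound 1 to compound 2 (beyond the scatter) lying beyond it. Compound 2 and compound 3 are separated by a number 0.19 log units higher from compound 2 to compound 3 (within the scatter).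

Next in line is compound 4 `CCc1cccc2nc(N3CCN(C)CC3)oc12`, not yet measured in this assay. Against compound 1 the change is hydrogen in place of methyl on an aromatic carbon. Within the data shown here, no measured step removes a methyl from an aromatic carbon of the shared core, so the precedent is indirect. The closest one is the loss of a single carbon in a number 0.14 log units lower from compound 1 to compound 3 (within the scatter), which stayed within the scatter; the exchange a number 0.19 log units higher from compound 2 to compound 3 (within the scatter) also stayed within it. Only a number 0.33 log units lower from compound 1 to compound 2 (beyond the scatter) went beyond the scatter, and that involved a methoxy rather than a hydrogen. On that basis the estimated step of a number 0.16 log units lower from compound 1 to compound 4 (within the scatter) is expected to stay within the scatter. The estimate for compound 4 in this assay is 6.3, with a range from 5.8 to 6.8.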

Compound 4, negative logarithm of the half-maximal effective concentration: 5.48
The estimate for compound 4 lay 0.82 log units above the measured number; the whole stated range lies above it.
By their numbers in this assay, from the lowest: compound 4; then compounds 2, 3 and 1 (each within the scatter of the next, the first and the last beyond it).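

Among these compounds, the methyl on the aromatic carbon para to a fused ring and meta to an ethyl group matters in this assay: its replacement by hydrogen gives a number 0.98 log units lower from compound 1 to compound 4 (beyond the scatter), the largest step so far. Among the compounds shown here, removing a single carbon elsewhere gives only a number 0.14 log units lower from compound 1 to compound 3 (within the scatter), so in this comparison with compound 1 the methyl on the aromatic ring is far less dispensable than the terminal carbon of the ethyl group, and the earlier compounds, which all carry this methyl, could not show this. The measurements shown give no account of why this hydrogen for methyl change costs so much.

The compounds shown leave open whether another group at this position, such as chlorine, trifluoromethyl or a propyl chain, would match, exceed or fall short of the methyl of compound 1. They also leave open whether hydrogen here would cost as much with methoxy in place of ethyl on the shared core, since this change has been read only against the ethyl-bearing compound 1.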